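Cytotoxicity limits and the loss of a chain methyl

The source may hold more compounds than are shown below. What is called first, only, known or untested is meant among the compounds shown, and "the series" means these compounds.

Compound 1 `CCO/N=C(/c1ccc(Br)cc1)C1CCN(C(C)CCNC(=O)c2c(C)cc[n+]([O-])c2C)CC1`: > 177000 nM
Compound 2 `CCO/N=C(/c1ccc(Br)cc1)C1CCN(C(C)CCN(C)C(=O)c2c(C)cc[n+]([O-])c2C)CC1`: > 182000 nM

In an ADME assay on PBMC cells (Homo sapiens) for cytotoxicity (on this read-out higher numbers stand for lower toxicity in this test and lower numbers for higher toxicity in this test), compound 1 gives > 177000 nM, and this is a limit, not a number. Compound 2 gives > 182000 nM, which is also a limit. Compound 3 `CCO/N=C(/c1ccc(Br)cc1)C1CCN(CCCNC(=O)c2c(C)cc[n+]([O-])c2C)CC1` awaits measurement in this assay. It departs from compound 1 by one change, hydrogen in place of methyl on a saturated chain carbon bound to an amine nitrogen in a ring and a saturated chain carbon. Among the compounds with values here, the one measured step, a step that the two limits leave unreadable from compound 1 to compound 2, lies at a different place and offers no readable size. Within the data shown here, no measured step covers the changed place, so the expectation rests on the two limits alone. The expected step that the limit leaves unreadable from compound 1 to compound 3 stays within the usual scatter. For compound 3 the estimated value is 180000 nM, with an expected range from 90000 nM to 260000 nM.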

Compound 3, half-maximal cytotoxic concentration: 7500 nM
Beside the measured number, compound 3's estimate is 24-fold (1.38 log units) above it, outside the stated range (below it).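

In this assay, hydrogen in place of methyl on a saturated chain carbon bound to an amine nitrogen in a ring and a saturated chain carbon brings an at least 23-fold lower number from compound 1 to compound 3 (1.37 log units; beyond the scatter), which means more toxicity in this test. Compounds 1 and 2 both ended in limits, so they could not show that any single change moves this read-out. Compound 3 gives a true number of 7500 nM and marks this chain methyl as a place where one carbon counts. Nothing in the data shown tells why this one methyl has such an effect.

The compounds shown leave open whether an ethyl group on that same carbon would keep the read-out at a limit or bring it down as hydrogen does. They also leave open whether a methyl on the amide-type nitrogen of compound 3 would change its number.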